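The source may report more compounds than this note shows. Statements on the series, on what has been measured and on what is new or still open speak of the compounds shown alone.

Measured so far in an ADME assay on Vero cells (Chlorocebus sabaeus) for cytotoxicity, read by sulforhodamine B assay, with a stated time of 72 h; on this read-out lower numbers stand for stronger inhibition and higher numbers for weaker inhibition:
- compound 1 `CN1Cc2ccc(OCc3ccc(-c4ccccc4)cc3)cc2[C@@H](O)C1`: 23000 nM
- compound 2 `CN1Cc2ccc(OCc3ccc(-c4ccc(-c5ccccc5)cc4)cc3)cc2[C@@H](O)C1`: 280 nM
- compound 3 `OC1CN(Cc2ccccc2)Cc2ccc(OCc3ccccc3)cc21`: 31800 nM

Compound 2 differs from compound 1 by phenyl in place of hydrogen on an aromatic carbon, and this gives an 82-fold lower number from compound 1 to compound 2 (1.91 log units; beyond the scatter). Compound 3 and compound 1 have the same atoms joined differently; the difference between the two cores is not broken down here. Compound 3 and compound 1 lie within the scatter of each other in this assay.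

Compound 4 `OC1CN(Cc2ccccc2)Cc2ccc(OCc3ccc(-c4ccccc4)cc3)cc21` is not yet measured. It differs from compound 3 by phenyl in place of hydrogen on an aromatic carbon, the same change as from compound 1 to compound 2. Resting on the single earlier step of an 82-fold lower number from compound 1 to compound 2 (1.91 log units; beyond the scatter) and on compound 3 at 31800 nM, a step of a 53-fold lower number from compound 3 to compound 4 (1.72 log units; beyond the scatter) is expected in this assay, with some widening for the unbroken core difference. Compound 4 is estimated at 600 nM, between 150 nM and 3000 nM.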

Compound 4, half-maximal inhibitory concentration: 14800 nM
Beside the measured number, compound 4's estimate is 25-fold (1.39 log units) below it, outside the stated range (above it).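

In this assay, phenyl in place of hydrogen on an aromatic carbon gives a 2.1-fold lower number from compound 3 to compound 4 (0.33 log units; beyond the scatter). The number falls on both cores, but the size of the step does not carry from one core to the other: the same change on two cores in this assay, an 82-fold lower number (1.91 log units; beyond the scatter) from compound 1 to compound 2 and a 2.1-fold lower number (0.33 log units; beyond the scatter) from compound 3 to compound 4, 38-fold (1.58 log units) apart, beyond the scatter of two such steps. These two steps set no rule for any further core, and the difference between the two cores is not broken down, so the gap cannot be assigned to any one part of them.

The compounds shown leave open how a pyridyl ring or a carboxylic acid in the same place would read in this assay. They also leave open whether a step of either size would recur on a third core.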